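This account rests on a few compounds, and the source may have more. Where it says the series, first, only, none or still open, it means among the compounds named here.

Compound 1, with the structure `Cc1cc(Cl)ccc1C(=O)N(C)c1cccnc1`, is the starting point of this short series, and it is tested in an ADME assay on cells for inhibition of cytochrome P450 11B1, mitochondrial (Homo sapiens), read by HTRF; a higher number here means a weaker inhibitor, a lower number a stronger inhibitor. In this assay compound 1 gives > 3000 nM, which is a limit of the assay and not a number. Compound 2, with the structure `CN(C(=O)c1ccc(C#N)cc1)c1cccnc1`, is a close relative. In this assay compound 2 gives > 3000 nM, again a limit rather than a number. Compound 3, with the structure `CCC(=O)N[C@@H]1CCCc2c1cncc2N1C(=O)c2ccc(Cl)cc2[C@H]1CC`, is built on a different frame. In this assay compound 3 gives 10200 nM. Compound 1 therefore stands at the limit of > 3000 nM in this assay, at which 2 of the 3 values shown sit, and its place relative to compound 3 cannot be fixed from what is shown.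

Compound 4, with the structure `CN(C(=O)c1ccc(Cl)cc1F)c1cccnc1`, has not yet been measured. It differs from compound 1 by fluoro in place of methyl on an aromatic carbon. Among the compounds with values here, no measured step of this kind exists here, so the step from compound 1 to compound 4 in this assay is expected to be a step that the limit leaves unreadable from compound 1 to compound 4, nothing beyond the scatter. Compound 4 is expected to give 5000 nM in this assay, within 2000 nM to 15000 nM, with a real chance that only a limit is reported again.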

Compound 4, half-maximal inhibitory concentration: > 3000 nM
Compound 4: only a limit was reported; the forecaster's own chance of this, stated with the estimate: 60%; the middle value is on the limit's open side.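

Compound 1 and compound 4 both give only a limit of the assay and not a number, so no step between them can be read for fluoro in place of methyl: the limit of > 3000 nM in this assay, at which 3 of the 4 values shown sit.

As far as these compounds go, what stays open is where compound 1, compound 2 and compound 4 truly lie in this assay, and whether this exchange changes anything there.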